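Methyl to sec-butyl on the chain

This account rests on a few compounds, and the source may have more. Where it says the series, first, only, none or still open, it means among the compounds named here.

a physicochemical assay for lipophilicity (a lower number here means a more polar compound, a higher number a more lipophilic compound), so far:
compound 1 `Cc1nc(C)c(C(=O)Oc2ccc(-c3cc(=O)c4c(O)c(O)c(O)cc4o3)cc2)nc1C` gives 3.01
compound 2 `Cc1nc(C)c(COC(=O)N[C@H](C)C(=O)Oc2ccc(-c3cc(=O)c4c(O)c(O)c(O)cc4o3)cc2)nc1C` gives 1.53

Compound 2 holds the lower number of the two, and its gap to compound 1 lies beyond the usual scatter. The change from compound 2 to compound 3 `CC[C@H](C)[C@@H](NC(=O)OCc1nc(C)c(C)nc1C)C(=O)Oc1ccc(-c2cc(=O)c3c(O)c(O)c(O)cc3o2)cc1` is sec-butyl in place of methyl on a saturated chain carbon bound to an amide-type nitrogen and a carbonyl carbon and amounts to sec-butyl in place of methyl on a saturated chain carbon bound to an amide-type nitrogen and a carbonyl carbon. Going by the values given here, no measured pair shows this change, so what follows is judgement alone. A rise in this assay beyond the scatter is expected, an estimated a number 1.07 log units higher from compound 2 to compound 3 (beyond the scatter) in size. For compound 3 the expected value is 2.6 within a range of 2 to 3.2 in this estimate.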

Compound 3, partition coefficient: 2.83
Compound 3: middle estimate off by 0.23 log units, on the low side; the range from low to high includes it.
By their numbers in this assay, from the lowest: compound 2; then compounds 3 and 1 (each within the scatter of the next).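

In this assay, sec-butyl in place of methyl on a saturated chain carbon bound to an amide-type nitrogen and a carbonyl carbon gives a number 1.30 log units higher from compound 2 to compound 3 (beyond the scatter). Going by these compounds alone, this is the only pair here that differs in one place, and it shows that the number responds strongly to the group at this position. No measurement here accounts for the size of this step.

With only methyl and sec-butyl shown, it remains open how an intermediate ethyl group, a longer chain, or a chain carrying an amine or a carboxylic acid would behave here. From the compounds shown here alone, whether the step would hold on another core also remains open.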